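Methoxy on the benzyl ester phenyl: compound 2 to 4

The source may hold more compounds than are shown below. What is called first, only, known or untested is meant among the compounds shown, and "the series" means these compounds.

Measured in a functional assay on A2780 cells (Homo sapiens) for antiproliferative activity, read by MTT assay, with a stated time of 48 h; on this read-out lower numbers stand for stronger inhibition of growth and higher numbers for weaker inhibition of growth:
- compound 1 `CCCOC(=O)N1N=C(c2ccccc2)CC1c1cc(OC)c(OC)c(OC)c1`: 10800 nM
- compound 2 `COc1cc(C2CC(c3ccccc3)=NN2C(=O)OCc2ccccc2)cc(OC)c1OC`: > 10000 nM (a limit)
- compound 3 `CCCOC(=O)N1N=C(c2cccc(OC)c2)CC1c1cc(OC)c(OC)c(OC)c1`: > 10000 nM (a limit)

Compound 2 has no number, only a limit of > 10000 nM. Compound 3 is also a limit, > 10000 nM. For the measured compounds named here, the only numerical value in this assay is that compound 1 gives 10800 nM.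

The step to compound 4 `COc1cccc(C2=NN(C(=O)OCc3ccccc3)C(c3cc(OC)c(OC)c(OC)c3)C2)c1` is methoxy in place of hydrogen on an aromatic carbon, phenyl to 3-methoxyphenyl. The same replacement was measured as a step that the limit leaves unreadable from compound 1 to compound 3. The ester change appears as a step that the limit leaves unreadable from compound 1 to compound 2. Neither gives a size to carry over because of the limit of > 10000 nM in this assay, at which 2 of the 3 values shown sit.

No step beyond the scatter is therefore expected, and a further limit is the likeliest report. The expected change is a step that the limit leaves unreadable from compound 2 to compound 4. For compound 4 the estimated value is 15000 nM, with an expected range from 7000 nM to 40000 nM.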

Compound 4, concentration for 50% growth inhibition: > 10000 nM
Compound 4 ended at the assay's limit; the forecaster's own chance of this, stated with the estimate: 75%; the middle value does not contradict the limit.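

Compound 4 gives > 10000 nM, a limit and not a number, so no new step to compound 4 can be read from compound 2 or compound 3: the limit of > 10000 nM in this assay, at which 3 of the 4 values shown sit.

The compounds shown leave open how far either the methoxy or the phenyl in place of ethyl shifts growth inhibition.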